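The source may report more compounds than this note shows. Statements on the series, on what has been measured and on what is new or still open speak of the compounds shown alone.

Compound 1 `COC(=O)[C@@H](NC(=O)CCC(=O)Oc1ccc(C[C@H]2C(=O)OC[C@@H]2Cc2ccc(OC)c(OC)c2)cc1OC)c1c[nH]c2ccccc12`: >= 600000 nM
Compound 2 `COc1ccc(C[C@H]2COC(=O)[C@@H]2Cc2ccc(OCC(=O)Nc3ccc(C)cc3)c(OC)c2)cc1OC`: 228000 nM
Compound 3 `COc1ccc(C[C@H]2COC(=O)[C@@H]2Cc2ccc(OCc3cn(Cc4ccccc4F)nn3)c(OC)c2)cc1OC`: >= 600000 nM

In an ADME assay on HeLa cells (Homo sapiens) for cytotoxicity, read by MTT assay (on this read-out higher numbers stand for weaker inhibition and lower numbers for stronger inhibition), compound 1 reaches only the limit of the assay, >= 600000 nM, which is a limit rather than a number. Compound 3 likewise stops at the limit, >= 600000 nM. Compound 2 gives a numerical value of 228000 nM. Compound 1 therefore stands at the limit of >= 600000 nM in this assay, at which 2 of the 3 values shown sit, the upper edge of what the assay reports. The untested compound 4 `COC(=O)[C@@H](NC(=O)CCC(=O)Oc1ccc(C[C@H]2C(=O)OC[C@@H]2Cc2ccc(OC)c(OC)c2)cc1OC)C(C)C` differs from compound 1 by isopropyl in place of 1H-indol-3-yl on a saturated chain carbon bound to an amide-type nitrogen and a carbonyl carbon. Among the measured compounds shown here, no step between measured compounds exists to gauge this exchange. From compound 1 to compound 4 a step of a number no higher from compound 1 to compound 4 (the limit leaves the size open) is expected, nothing beyond the scatter. Compound 4 is expected to give 600000 nM, in a range from 300000 nM to 1200000 nM, probably again reported as a limit.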

Compound 4, half-maximal inhibitory concentration: 64000 nM
Compound 4: middle estimate off by 9.4-fold (0.97 log units), on the high side, and the stated range ends above it.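

In this assay, among the compounds shown here, this position is the first place where a single exchange can be read: isopropyl in place of 1H-indol-3-yl on a saturated chain carbon bound to an amide-type nitrogen and a carbonyl carbon gives an at least 9.3-fold lower number from compound 1 to compound 4 (0.97 log units; beyond the scatter). The change therefore moves the read-out beyond the scatter, towards stronger inhibition. Its full size stays unknown, as compound 1 gives only a limit: the limit of >= 600000 nM in this assay, at which 2 of the 4 values shown sit.

The compounds shown leave open how a methyl, a benzyl or a phenyl group would read at this carbon. They also cannot separate the loss of the rings from the loss of the indole hydrogen-bond donor.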